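A few compounds are considered here, and "the series" means these few. Any claim that something is new, unique, unknown or untested is made for them only; others in the source may bear on it.

Compound 1 `O=C(Nc1cccc(-c2oc3cc(-c4ccc(F)cc4)ccc3c(=O)c2O)c1)c1ccc(Cl)cc1` gives 4030 nM in a functional assay on HCC1937 cells (Homo sapiens) for antiproliferative activity, read by CCK-8 assay, with a stated time of 72 h; a lower number here means a stronger inhibitor, a higher number a weaker inhibitor. Compound 2 `O=C(Nc1cccc(-c2oc3cc(-c4ccc(F)cc4)ccc3c(=O)c2O)c1)c1ccc(C(F)(F)F)cc1` gives 7350 nM in this assay, the higher of the two numbers, although the step of a 1.8-fold higher number from compound 1 to compound 2 (0.26 log units; within the scatter) stays within the scatter. Compound 3 `COc1cc(OC)cc(C(=O)Nc2cccc(-c3oc4cc(-c5ccc(F)cc5)ccc4c(=O)c3O)c2)c1` carries 3,5-dimethoxyphenyl in place of 4-(trifluoromethyl)phenyl on a carbonyl carbon. Among the measured compounds shown here, no measured step covers an exchange of this kind. For the measured compounds named here, the only step in the set, a 1.8-fold higher number from compound 1 to compound 2 (0.26 log units; within the scatter), also exchanged the group on the carbonyl carbon and stayed within the scatter, so no move beyond the scatter is expected here either. For compound 3 the estimate in this assay is 5500 nM, between 2000 nM and 15000 nM. This corresponds to an expected step of a 1.3-fold lower number from compound 2 to compound 3 (0.13 log units; within the scatter).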

Compound 3, half-maximal inhibitory concentration: 6250 nM
Compound 3: middle estimate off by 1.1-fold (0.06 log units), on the low side, within the range that was stated.
By their numbers in this assay, from the lowest: compounds 1, 3 and 2 (each within the scatter of the next).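

On the carbonyl carbon, the two hydrogen-bond acceptors of 3,5-dimethoxyphenyl enter where 4-(trifluoromethyl)phenyl has none, yet this assay shows a 1.2-fold lower number from compound 2 to compound 3 (0.07 log units; within the scatter) and, against the chloro analogue, a 1.6-fold higher number from compound 1 to compound 3 (0.19 log units; within the scatter) as well. This position therefore shows no readable difference among the three aryl groups, even with a disubstituted ring in place of a monosubstituted one. No available evidence explains this result. Still open, from the compounds shown here alone, is whether a phenyl ring carrying an amine or a carboxylic acid at this position would move the number beyond the scatter.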